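The compounds below may be only part of what the source reports. "The series", "measured", "known", "first", "only" and "open" are said of these compounds alone.

In a functional assay on Raji cells (Homo sapiens) for cytotoxicity, read by CCK-8 assay, with a stated time of 24 h (on this read-out higher numbers stand for weaker inhibition and lower numbers for stronger inhibition), three compounds sharing one core have been measured: compound 1 `C=CC(=O)N1C(=O)CC(c2ccc(C(F)(F)F)cc2)Sc2ccccc21` gives 47600 nM, compound 2 `C=CC(=O)N1C(=O)CC(c2ccc(C)cc2)Sc2ccccc21` gives 75500 nM and compound 3 `C=CC(=O)N1C(=O)CC(c2ccc(OC)cc2)Sc2ccccc21` gives 43300 nM. Compound 3 does not stand apart from the other two, as the steps to it show: a 1.1-fold lower number from compound 1 to compound 3 (0.04 log units; within the scatter) and a 1.7-fold lower number from compound 2 to compound 3 (0.24 log units; within the scatter). The remaining step, a 1.6-fold higher number from compound 1 to compound 2 (0.20 log units; within the scatter), is of the same kind.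

Compound 4 `C=CC(=O)N1C(=O)CC(C)Sc2ccccc21` differs from compound 3 in one place, with methyl in place of 4-methoxyphenyl on a saturated ring carbon, next to the ring sulfur (methyl in place of 4-methoxyphenyl on a saturated ring carbon). The three measured steps bear on this change only loosely. Each exchanges one small group on an aromatic carbon and keeps the aromatic ring, whereas here the whole ring leaves. For the measured compounds named here, no measured compound lacks that ring, so the data give no direct guide to the size or direction of this step. Those three steps offer no evidence of a large shift, so only a modest move towards a higher number is expected, with wide uncertainty in either direction. The expected step is a 1.6-fold higher number from compound 3 to compound 4 (0.21 log units; within the scatter). Compound 4 is estimated at 70000 nM, with an expected range from 25000 nM to 180000 nM.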

Compound 4, half-maximal inhibitory concentration: 837000 nM
Estimate against measurement, compound 4: 12-fold (1.08 log units) below; the measured number lies above the stated range.
By their numbers in this assay, from the lowest: compounds 3, 1 and 2 (each within the scatter of the next); then compound 4.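

In this assay, the change at the saturated ring carbon, next to the ring sulfur, is large: methyl in place of 4-methoxyphenyl gives a 19-fold higher number from compound 3 to compound 4 (1.29 log units; beyond the scatter), and methyl in place of 4-methylphenyl gives an 11-fold higher number from compound 2 to compound 4 (1.04 log units; beyond the scatter). The earlier compounds shown here all kept an aromatic ring at this carbon and differed only in the small group it carries, and those exchanges stayed within the scatter; these two steps show that replacing the whole ring with methyl weakens inhibition far more than any of those exchanges did. Nothing available here accounts for this rise in the number.

The compounds shown leave open whether an aromatic ring itself is needed at this carbon or whether a non-aromatic group such as cyclohexyl, or a longer chain such as n-butyl, would serve as well. Every compound shown also carries the vinylcarbonyl group, and whether a propanoyl group in its place would keep the numbers of compound 1, compound 2 and compound 3 stays open.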